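The source may hold more compounds than are shown below. What is called first, only, known or untested is meant among the compounds shown, and "the series" means these compounds.

The compounds share one core, seen in compound 1 `O=C(NO)c1ccc(NCCOc2ccc3cc2COC/C=C/COCc2cccc(c2)-c2ccnc(n2)N3)cc1`, and differ only in the group hung from it. In an assay on Sf9 cells for inhibition of protein deacetylase HDAC6 (Homo sapiens), read by fluorescence, with a stated time of 2 h (on this read-out lower numbers stand for stronger inhibition and higher numbers for weaker inhibition), compound 1 gives 395 nM. Compound 2 `O=C(O)c1cccc(NCCOc2ccc3cc2COC/C=C/COCc2cccc(c2)-c2ccnc(n2)N3)c1` gives 53000 nM in this assay, and compound 3 `O=C(O)CCCCCCC(=O)Nc1ccc(NCCOc2ccc3cc2COC/C=C/COCc2cccc(c2)-c2ccnc(n2)N3)cc1` gives 2600 nM. Compound 2 therefore stands at the highest number of the three, the weakest inhibition shown; its gaps to compound 3 and to compound 1 both lie beyond the scatter. The step of a 130-fold higher number from compound 1 to compound 2 (2.13 log units; beyond the scatter) is large, while the step of a 6.6-fold higher number from compound 1 to compound 3 (0.82 log units; beyond the scatter) is modest.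

Compound 4 `O=C(O)CCCCCCCOc1ccc2cc1COC/C=C/COCc1cccc(c1)-c1ccnc(n1)N2` has not yet been measured. Against compound 2 it shows the change (5-carboxypentyl in place of (3-carboxyphenyl)amino on a saturated chain carbon, two bonds along the chain from an oxygen on an aromatic ring). Within the data shown here, no measured step makes exactly this change. Compound 3 shows that a carboxylic acid at the end of a chain can give a number well under that of compound 2, yet compound 4 keeps neither the hydroxycarbamoyl of compound 1 nor the amide of compound 3, so the evidence stays thin. In this assay compound 4 is expected to give 20000 nM, within a range from 4000 nM to 100000 nM. That would mean an expected step of a 2.7-fold lower number from compound 2 to compound 4 (0.42 log units; beyond the scatter), a moderate fall in number that could also turn out flat.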

Compound 4, half-maximal inhibitory concentration: 10000 nM
Compound 4: middle estimate off by 2.0-fold (0.30 log units), on the high side; measured number inside the range.
By their numbers in this assay, from the lowest: compound 1; then compound 3; then compound 4; then compound 2.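

In this assay, putting 5-carboxypentyl in place of (3-carboxyphenyl)amino gives a 5.3-fold lower number from compound 2 to compound 4 (0.72 log units; beyond the scatter). At this position, then, a carboxylic acid on a plain saturated chain, with no aromatic ring and no amine nitrogen in the group, gives a lower number than the acid on the aromatic ring of compound 2. The step of a 25-fold higher number from compound 1 to compound 4 (1.40 log units; beyond the scatter) is large, however, so this chain acid does not match the (4-(hydroxycarbamoyl)phenyl)amino group, and compound 1 keeps the lowest number of the four; no measurement shown here explains either step.

Between compound 1 and compound 4, the end group and the group carrying it change together, so it remains open whether a hydroxycarbamoyl group on the end of a saturated chain, in place of the carboxylic acid of compound 4, would lower the number. Also open, on these data alone, is how a shorter or a longer chain ending in a carboxylic acid would compare with the 5-carboxypentyl group, and whether an amine nitrogen within such a chain would change the number.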